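Aryl Swap at the Chain Carbon: Expected Topoisomerase Inhibition

This account rests on a few compounds, and the source may have more. Where it says the series, first, only, none or still open, it means among the compounds named here.

Three compounds share one core and differ only in the aryl group carried on a double-bonded chain carbon. In an assay on isolated protein for inhibition of DNA topoisomerase 1 (Homo sapiens), with a stated time of 30 min, tested at 100 uM (a higher number here means a stronger effect of the compound at the concentration tested, a lower number a weaker effect), compound 1 `O=C(CN1CCN(c2cc3c(cc2F)c(=O)c(C(=O)O)cn3C2CC2)CC1)Nc1ccc(C(=O)/C=C/c2ccc(Cl)cc2)cc1` gives 67.5%, compound 2 `COc1ccc(/C=C/C(=O)c2ccc(NC(=O)CN3CCN(c4cc5c(cc4F)c(=O)c(C(=O)O)cn5C4CC4)CC3)cc2)cc1` gives 67.6%, and compound 3 `COc1cc(/C=C/C(=O)c2ccc(NC(=O)CN3CCN(c4cc5c(cc4F)c(=O)c(C(=O)O)cn5C4CC4)CC3)cc2)cc(OC)c1OC` gives 67.4%. On the numbers shown, compound 3 stands lowest of the three, yet both gaps to its neighbours lie within the scatter: a number 0.1 percentage points lower from compound 1 to compound 3 (within the scatter) and a number 0.2 percentage points lower from compound 2 to compound 3 (within the scatter). Compound 4 `Cc1ccc(/C=C/C(=O)c2ccc(NC(=O)CN3CCN(c4cc5c(cc4F)c(=O)c(C(=O)O)cn5C4CC4)CC3)cc2)c(C)c1` has not yet been measured and differs from compound 3 as follows: 2,4-dimethylphenyl in place of 3,4,5-trimethoxyphenyl on a double-bonded chain carbon bound to a double-bonded chain carbon. The measured steps that bear on this change are a number 0.1 percentage points higher from compound 1 to compound 2 (within the scatter), a number 0.1 percentage points lower from compound 1 to compound 3 (within the scatter) and a number 0.2 percentage points lower from compound 2 to compound 3 (within the scatter), each within the scatter, so three different aryl groups on that chain carbon gave inhibition that cannot be told apart. For compound 4 no step beyond the scatter is therefore expected in this assay, and the estimated step is a number 0.4 percentage points lower from compound 3 to compound 4 (within the scatter). Compound 4 is expected to give 67%, with a range of 57% to 76%.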

Compound 4, a percentage reported as inhibition, at one concentration (the size of the read-out at that concentration, not a potency) in the DNA topoisomerase 1 assay: 85.1%
Estimate against measurement, compound 4: 18.1 percentage points below; the whole stated range lies below it.
By their numbers in the DNA topoisomerase 1 assay, from the lowest: compounds 3, 1 and 2 (each within the scatter of the next); then compound 4.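

In the DNA topoisomerase 1 assay compound 4 gives 85.1%, so this position proved able to move the read-out after all (a number 17.7 percentage points higher from compound 3 to compound 4 (beyond the scatter); a number 17.5 percentage points higher from compound 2 to compound 4 (beyond the scatter); a number 17.6 percentage points higher from compound 1 to compound 4 (beyond the scatter)). The 2,4-dimethylphenyl group thus stands apart from the 3,4,5-trimethoxyphenyl, 4-methoxyphenyl and 4-chlorophenyl groups, which remain within the scatter of one another, while in a physicochemical assay for solubility, at pH 6.9 (a lower number here means a less soluble compound, a higher number a more soluble compound), compound 3 gives 2.13 ug/mL and compound 4 gives 2.12 ug/mL, and the two cannot be told apart (a 1.0-fold lower number from compound 3 to compound 4 (0.00 log units; within the scatter)). No measurement among those shown accounts for the gain in inhibition.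

The compounds shown leave open whether the gain needs both methyl groups or would also appear with 4-methylphenyl alone. They also leave open whether an amine or a hydroxyl group on the same aryl ring, or a 2,4-dichlorophenyl group in its place, would keep it.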